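A few compounds are considered here, and "the series" means these few. Any claim that something is new, unique, unknown or untested is made for them only; others in the source may bear on it.

In an assay on cells for displacement of a labelled ligand from corticotropin-releasing factor receptor 1 (Homo sapiens), with a stated time of 100 min (on this read-out higher numbers stand for weaker inhibition and lower numbers for stronger inhibition), compound 2 `Cc1cc(C)c(-n2c(Cl)cn3c(CN(CCC(F)(F)F)Cc4ccc(F)cc4)c(C(F)(F)F)nc23)c(C)c1` gives 34 nM, the higher of the two numbers in hand. Among the compounds with values here, compound 1 `Cc1cc(C)c(-n2c(Cl)cn3c(CN(CCC(F)(F)F)CC4CC4)c(C(F)(F)F)nc23)c(C)c1` gives 16 nM; the only measured step, a 2.1-fold higher number from compound 1 to compound 2 (0.33 log units; beyond the scatter), changes the group on a saturated chain carbon bound to the amine nitrogen. Compound 3 `CCCN(Cc1ccc(F)cc1)Cc1c(C(F)(F)F)nc2n(-c3c(C)cc(C)cc3C)c(Cl)cn12` differs from compound 2 by methyl in place of trifluoromethyl on a saturated chain carbon, two bonds along the chain from an amine nitrogen. Within the data shown here, no measured step touches that place, so nothing in hand bears on the change. Compound 3 is therefore expected to show a 1.2-fold higher number from compound 2 to compound 3 (0.07 log units; within the scatter), nothing beyond the scatter. Compound 3 is estimated at 40 nM in this assay, between 12 nM and 130 nM.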

Compound 3, inhibition constant: 350 nM
The estimate for compound 3 lay 8.8-fold (0.94 log units) below the measured number, outside the stated range (above it).
By their numbers in this assay, from the lowest: compound 1; then compound 2; then compound 3.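

Changing 3,3,3-trifluoropropyl to propyl gives a large step (a 10-fold higher number from compound 2 to compound 3 (1.01 log units; beyond the scatter)), far bigger than the modest earlier step at a different group (a 2.1-fold higher number from compound 1 to compound 2 (0.33 log units; beyond the scatter)). Within the data shown here, this is the first sign that the trifluoromethyl end of this chain matters strongly for the number. No evidence in hand explains this step.

From the compounds shown here alone, whether a chain ending in a hydroxyl group or nitrile, or a longer chain such as butyl, would match compound 2 stays open. So does whether this change would cost as much on compound 1.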